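Trading 4-methoxyphenyl for 3-bromophenyl on a carboxy compound

This account rests on a few compounds, and the source may have more. Where it says the series, first, only, none or still open, it means among the compounds named here.

For the measured compounds named here, in a functional assay on KB cells (Homo sapiens) for antiproliferative activity, read by MTT assay, with a stated time of 72 h (on this read-out higher numbers stand for weaker inhibition and lower numbers for stronger inhibition), compound 2 (`COc1ccc(-c2sc(C(=O)O)cc2-c2cc(OC)c(OC)c(OC)c2)cc1`) gives 10400 nM as the only actual number so far. Compound 3 (`COc1cc(-c2cc(C(=O)O)sc2-c2cccc(Br)c2)cc(OC)c1OC`) keeps the carboxy group and the rest of the core of compound 2 but changes one group (3-bromophenyl in place of 4-methoxyphenyl on an aromatic carbon): 3-bromophenyl in place of 4-methoxyphenyl on an aromatic carbon next to the ring sulfur. Compound 1 (`CCOC(=O)c1cc(-c2cc(OC)c(OC)c(OC)c2)c(-c2cccc(Br)c2)s1`) also carries 3-bromophenyl and reads > 100000 nM as a limit of the assay rather than a number, which tilts the expectation toward weaker inhibition. Going by the values given here, no measured pair isolates this swap, so its size remains uncertain. In this assay the expected change is a 1.9-fold higher number from compound 2 to compound 3 (0.28 log units; within the scatter) as a modest move toward weaker inhibition. Compound 3 is estimated at 20000 nM with an expected range of 6000 nM to 70000 nM in this assay.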

Compound 3, half-maximal inhibitory concentration: 32300 nM
Estimate against measurement, compound 3: 1.6-fold (0.21 log units) below; the range from low to high includes it.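

In this assay, this change now has a size of its own with the carboxy group kept: 3-bromophenyl in place of 4-methoxyphenyl gives a 3.1-fold higher number from compound 2 to compound 3 (0.49 log units; beyond the scatter), a move toward weaker inhibition. For the compounds shown here, the carboxy group can also be compared with its ethyl-bearing counterpart for the first time, as hydrogen in place of ethyl on an oxygen next to a carbonyl group gives an at least 3.0-fold lower number from compound 1 to compound 3 (0.49 log units; beyond the scatter). That second step rests on a limit for compound 1, not on a number: the limit of > 100000 nM in this assay, at which 1 of the 3 values shown sits.

The swap changes both the group and its place on the phenyl ring, so 4-bromophenyl or 3-methoxyphenyl would be needed to separate those two changes. From the compounds shown here alone, it also remains open whether the 4-methoxyphenyl compound responds in the same way when its carboxy group carries an ethyl group.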